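Swapping a methoxyphenyl for a difluorophenyl beside the ketone

The source may hold more compounds than are shown below. What is called first, only, known or untested is meant among the compounds shown, and "the series" means these compounds.

Measured compounds:
compound 1 `COc1ccc(-c2cc(/C=C/C(=O)c3ccc(OC)c(OC)c3)[nH]n2)cc1`, in a functional assay on M14 cells (Homo sapiens) for inhibition, read by sulforhodamine B assay, with a stated time of 48 h (a higher number here means that more compound is tolerated, a lower number that less compound is tolerated), compound 1 gives 13800 nM
compound 2 `COc1ccc(-c2cc(/C=C/C(=O)c3cc(OC)c(OC)c(OC)c3)[nH]n2)cc1OC`, in this assay compound 2 gives 7540 nM
compound 3 `COc1ccc(C(=O)/C=C/c2cc(-c3cc(OC)c(OC)c(OC)c3)n[nH]2)cc1`, in this assay compound 3 gives > 100000 nM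

Compounds 1 and 2 each have a number in this assay. The value for compound 3 is not a number but a limit of the assay, so compound 3 stands at the limit of > 100000 nM in this assay, at which 1 of the 3 values shown sits, with no measured toxicity toward the cells at any concentration that was tested.

Compound 4 `COc1cc(-c2cc(/C=C/C(=O)c3ccc(F)c(F)c3)[nH]n2)cc(OC)c1OC` is the next compound to be measured, and it differs from compound 3 in a single place: 3,4-difluorophenyl in place of 4-methoxyphenyl on a carbonyl carbon. The shared core and the trimethoxyphenyl group on it stay as they are. Among the compounds with values here, since compound 3 gives only a limit, there is no number to step from, and no measured pair among the three compounds shows what this exchange does. The expectation for the step of an at least 1.6-fold lower number from compound 3 to compound 4 (0.22 log units; that floor lies within the scatter) is therefore modest, with a real chance that compound 4 also returns only a limit. Compound 4 is estimated at 60000 nM, between 15000 nM and 300000 nM.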

Compound 4, concentration lethal to 50% of the cells: > 100000 nM
Compound 4 gave a limit, no number; the forecaster's own chance of this, stated with the estimate: 50%; middle value at least 1.6-fold (0.22 log units) away from the limit.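

Within the data shown here, compound 3 and compound 4 both end at a limit of the assay rather than a number, so no step between them can be read: the limit of > 100000 nM in this assay, at which 2 of the 4 values shown sit.

The compounds shown leave open what 3,4-difluorophenyl in place of 4-methoxyphenyl on a carbonyl carbon does to the read-out in this assay.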